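From compound 2 to compound 3: a longer chain

A few compounds are considered here, and "the series" means these few. Any claim that something is new, unique, unknown or untested is made for them only; others in the source may bear on it.

- compound 1 `COc1ccc(N(C)c2nc(C)nc3ccccc23)cc1C(=O)OCCC[Se]C#N` gives 1180 nM in a functional assay on MDA-MB-231 cells (Homo sapiens) for inhibition, read by MTT assay, with a stated time of 48 h (a lower number here means a stronger inhibitor, a higher number a weaker inhibitor), as its measured value
- compound 2 `COc1ccc(N(C)c2nc(C)nc3ccccc23)cc1C(=O)OCCCC[Se]C#N` gives 554 nM in this assay as its measured value
- compound 3 `COc1ccc(N(C)c2nc(C)nc3ccccc23)cc1C(=O)OCCCCCC[Se]C#N` has not yet been measured

Of the two measured compounds, compound 2 holds the lower number in this assay and is the stronger inhibitor of the pair. Going on to compound 3 brings a group of 5 heavy atoms (3 carbon, 1 nitrogen, 1 selenium; no ring) in place of a group of 3 heavy atoms (1 carbon, 1 nitrogen, 1 selenium; no ring), on a saturated chain carbon, four bonds along the chain from an oxygen next to a carbonyl group and leaves the shared core untouched. Within the data shown here, only one measured step bears on this change, and it also lies on the chain: a 2.1-fold lower number from compound 1 to compound 2 (0.33 log units; beyond the scatter) is modest, beyond the scatter but not far beyond it. That single step cannot show whether the trend carries on, and no longer chain has been measured yet. Resting on a 2.1-fold lower number from compound 1 to compound 2 (0.33 log units; beyond the scatter) as the only guide, a further modest move towards a lower number is expected in this assay for the longer chain. The expected size is a 1.8-fold lower number from compound 2 to compound 3 (0.27 log units; within the scatter) as an estimate with wide margins. Compound 3 is estimated at 300 nM with an expected range from 110 nM to 750 nM in this assay.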

Compound 3, half-maximal inhibitory concentration: 2210 nM
Compound 3: the middle estimate sits 7.4-fold (0.87 log units) below what was measured; measured number outside the range, above it.
By their numbers in this assay, from the lowest: compound 2; then compounds 1 and 3 (each within the scatter of the next).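

In this assay, adding to the chain does not keep lowering the number: a 4.0-fold higher number from compound 2 to compound 3 (0.60 log units; beyond the scatter) runs against the earlier 2.1-fold lower number from compound 1 to compound 2 (0.33 log units; beyond the scatter), so the response at this position on the saturated chain changes direction across the three compounds, and compound 2 has the lowest number, with its steps to both others beyond the scatter. The ends of the series stay close, with a 1.9-fold higher number from compound 1 to compound 3 (0.27 log units; within the scatter), so the added chain length in compound 3 gives no separation from compound 1 that can be read in this assay. No evidence is available that accounts for this turn in the series.

The compounds shown leave open where between compound 2 and compound 3 the number starts to rise, and whether a chain of intermediate length would give a number close to that of compound 2 or one close to that of compound 3. They also leave open how a longer chain than that of compound 3 would behave, and whether the same turn would appear with an amide in place of the ester.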